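Piperazinyl Acetamide in Place of a Benzoxazolyl Thioether

The compounds below may be only part of what the source reports. "The series", "measured", "known", "first", "only" and "open" are said of these compounds alone.

Measured so far:
compound 1, `Cn1c(-c2ccc(NC(=O)CSc3nc4cc(Cl)ccc4o3)cc2)nc(-c2ccccc2)c1-c1ccccc1`, 40%
compound 2, `Cn1cnnc1SCC(=O)Nc1ccc(-c2nc(-c3ccccc3)c(-c3ccccc3)n2C)cc1`, 61.2%
compound 3, `CCN1CCN(CC(=O)Nc2ccc(-c3nc(-c4ccccc4)c(-c4ccccc4)n3C)cc2)CC1`, 32.8%

In a functional assay on MCF7 cells (Homo sapiens) for cytotoxicity, read by MTT assay, with a stated time of 24 h, tested at 16 ug/mL (on this read-out higher numbers stand for a stronger effect at the one concentration tested and lower numbers for a weaker effect), compound 1 gives 40%, the second highest of the three numbers; compound 3 sits within the scatter of it, while compound 2 lies beyond it. Compound 4 `CN(C)/C=C/N1CCN(CC(=O)Nc2ccc(-c3nc(-c4ccccc4)c(-c4ccccc4)n3C)cc2)CC1` differs from compound 1 in one place: 4-(2-(dimethylamino)ethenyl)piperazin-1-yl in place of (5-chloro-1,3-benzoxazol-2-yl)sulfanyl on a saturated chain carbon bound to a carbonyl carbon. The step that bears most directly on this change is a number 7.2 percentage points lower from compound 1 to compound 3 (within the scatter), where a piperazinyl group likewise replaced the thioether on the same carbon. The steps of a number 21.2 percentage points higher from compound 1 to compound 2 (beyond the scatter) and a number 28.4 percentage points lower from compound 2 to compound 3 (beyond the scatter) show that the thioether substituent itself matters, but neither involves a piperazinyl. For compound 4 the step of a number 4 percentage points lower from compound 1 to compound 4 (within the scatter) is therefore expected, not beyond the scatter. Compound 4 is estimated at 36%, with a range from 22% to 52%.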

Compound 4, a percentage reported as activity, at one concentration (the size of the read-out at that concentration, not a potency): 19.4%
Compound 4: the middle estimate sits 16.6 percentage points above what was measured; measured number outside the range, below it.
By their numbers in this assay, from the lowest: compound 4; then compounds 3 and 1 (each within the scatter of the next); then compound 2.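

In this assay the group on an amine nitrogen in a ring proves to matter: 2-(dimethylamino)ethenyl in place of ethyl gives a number 13.4 percentage points lower from compound 3 to compound 4 (beyond the scatter), so a piperazinyl replacement is not neutral in every form, as compound 3 alone had suggested. Against the thioethers the same group gives a number 20.6 percentage points lower from compound 1 to compound 4 (beyond the scatter) and a number 41.8 percentage points lower from compound 2 to compound 4 (beyond the scatter), the last being the largest step in the set. No measured evidence accounts for these steps. Open, from the compounds shown here alone, is whether a saturated 2-(dimethylamino)ethyl group on that nitrogen would read like ethyl or like 2-(dimethylamino)ethenyl.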